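Title: A Benzyl in Place of a Methylphenyl on the Thiourea Nitrogen

The source may report more compounds than this note shows. Statements on the series, on what has been measured and on what is new or still open speak of the compounds shown alone.

Three compounds built on one shared core were tested in a functional assay on HT-29 cells (Homo sapiens) for antiproliferative activity, read by sulforhodamine B assay, with a stated time of 72 h; a lower number here means a stronger inhibitor, a higher number a weaker inhibitor. Compound 1 `S=C(N/N=C/c1ccc2ccccc2n1)Nc1cccc(Cl)c1` gives 48100 nM, and compound 2 `S=C(N/N=C/c1ccc2ccccc2n1)Nc1cccc(Br)c1` gives 58900 nM. The step of a 1.2-fold higher number from compound 1 to compound 2 (0.09 log units; within the scatter) is small. Compound 3 `Cc1cccc(NC(=S)N/N=C/c2ccc3ccccc3n2)c1` gives only > 100000 nM, which is a limit of the assay rather than a number. For the measured compounds named here, the steps of an at least 2.0-fold higher number from compound 1 to compound 3 (0.31 log units; beyond the scatter) and an at least 1.6-fold higher number from compound 2 to compound 3 (0.22 log units; that floor lies within the scatter) are the only comparisons available. Compound 4 `S=C(NCc1ccccc1)N/N=C/c1ccc2ccccc2n1` differs from compound 3 by benzyl in place of 3-methylphenyl on an amide-type nitrogen. Going by the values given here, no measured step exchanges an aryl group for a benzyl group on that nitrogen, so the measured steps give no direction for this change, and the limit of > 100000 nM in this assay, at which 1 of the 3 values shown sits, marks where compound 3 sits. Compound 4 is therefore expected to stay near that limit, an estimated step of a number no higher from compound 3 to compound 4 (the limit leaves the size open). The estimate for compound 4 is 100000 nM, between 30000 nM and 300000 nM.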

Compound 4, half-maximal inhibitory concentration: 75700 nM
Beside the measured number, compound 4's estimate is 1.3-fold (0.12 log units) above it; measured number inside the range.
By their numbers in this assay, from the lowest: compounds 1, 2 and 4 (each within the scatter of the next). At a limit, above all of these: compound 3.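

The benzyl group on the amide-type nitrogen gives a measurable number in this assay, and that number cannot be told apart from those of the two halogen-bearing phenyl compounds: the steps are a 1.3-fold higher number from compound 2 to compound 4 (0.11 log units; within the scatter) and a 1.6-fold higher number from compound 1 to compound 4 (0.20 log units; within the scatter). The step of an at least 1.3-fold lower number from compound 3 to compound 4 (0.12 log units; that floor lies within the scatter) is only a floor, so it shows no clear gain over 3-methylphenyl. Compound 3 holds a limit and not a number: the limit of > 100000 nM in this assay, at which 1 of the 4 values shown sits.

Still open, on these data alone, is whether a phenethyl group, with its longer chain, or a cyclohexyl group on this same nitrogen would give a clearly lower number.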